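A few compounds are considered here, and "the series" means these few. Any claim that something is new, unique, unknown or untested is made for them only; others in the source may bear on it.

Compound 1 `CS(=O)(=O)Nc1ccc(-c2ccc3c(O)cccc3c2)cc1` is the parent of this small set. In an assay for binding affinity to 17-beta-hydroxysteroid dehydrogenase type 2 (Homo sapiens), with a stated time of 20 min, tested at 1 uM (a higher number here means more inhibition at the concentration tested (going by the name of the read-out), a lower number less inhibition), compound 1 gives 75%. Compound 2 `CS(=O)(=O)Nc1cccc(-c2ccc3c(O)cccc3c2)c1` is built from the same atoms joined differently; the difference between the two cores is not broken down here. In this assay compound 2 gives 22%. Compound 3 `CNC(=O)c1ccc(-c2ccc3c(O)cccc3c2)cc1` carries methylcarbamoyl in place of methanesulfonamido on an aromatic carbon, and in this assay compound 3 gives 13%, so that the step of a number 62 percentage points lower from compound 1 to compound 3 (beyond the scatter) is a large one. The numbers for compound 2 and compound 3 lie within the scatter of each other.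

Compound 4 `CNC(=O)c1cccc(-c2ccc3c(O)cccc3c2)c1` has not yet been measured. It carries methylcarbamoyl in place of methanesulfonamido on an aromatic carbon relative to compound 2, the same kind of change as that from compound 1 to compound 3, though the place differs: para to a large group there, meta to a large group here. Because compound 2 starts from 22%, the room for a fall is smaller, and the step is expected to be a number 14 percentage points lower from compound 2 to compound 4 (beyond the scatter). For compound 4 in this assay the estimate is 8%, between 0% and 25%.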

Compound 4, a percentage reported as inhibition, at one concentration (the size of the read-out at that concentration, not a potency): 43%
Beside the measured number, compound 4's estimate is 35 percentage points below it, and the stated range ends below it.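

Moved to the core of compound 2, the exchange of methanesulfonamido for methylcarbamoyl gives a number 21 percentage points higher from compound 2 to compound 4 (beyond the scatter) in this assay and so does not carry over from the core of compound 1 with the same direction or size: the same change on two cores in this assay, a number 62 percentage points lower (beyond the scatter) from compound 1 to compound 3 and a number 21 percentage points higher (beyond the scatter) from compound 2 to compound 4, 83 percentage points apart, beyond the scatter of two such steps. The outcome of this change in one core therefore cannot be used to predict its outcome in the other, and the two pairs do not support a single rule for the series. The comparison does not show why the direction differs, nor how the change would behave on any further core.

The compounds shown carry only these two groups, so it remains open whether a carboxylic acid, an amine or a longer chain in the same places would follow methanesulfonamido, methylcarbamoyl or neither. Each number is also a reading at a single concentration, so the potencies of these compounds remain open too.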